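This account rests on a few compounds, and the source may have more. Where it says the series, first, only, none or still open, it means among the compounds named here.

Measured so far:
- compound 1, `CN(C)CCCCCCOc1ccc2oc(-c3ccccc3)cc(=O)c2c1`: 335 nM
- compound 2, `CN(C)CCCCCCCCCOc1ccc2oc(-c3ccccc3)cc(=O)c2c1`: 202 nM
- compound 3, `O=c1cc(-c2ccccc2)oc2ccc(OCCCN3CCC(O)CC3)cc12`: 123 nM

In an assay on isolated protein (Cavia porcellus) with Sigma non-opioid intracellular receptor 1 (Homo sapiens) as the target, read by radioligand binding (on this read-out higher numbers stand for weaker inhibition and lower numbers for stronger inhibition), compound 3 shows the lowest number of the three, yet its gap to compound 2 is within the scatter, so no order between those two can be claimed; only compound 1 sits clearly higher, as a 2.7-fold lower number from compound 1 to compound 3 (0.44 log units; beyond the scatter) shows. Compound 4, `O=c1cc(-c2ccccc2)oc2ccc(OCCCCCCN3CCCCC3)cc12`, differs from compound 3 by 3-(piperidin-1-yl)propyl in place of 4-hydroxypiperidin-1-yl on a saturated chain carbon, three bonds along the chain from an oxygen on an aromatic ring. Within the data shown here, two measured steps bear on this change. Lengthening the chain between the aromatic oxygen and the amine gave a 1.7-fold lower number from compound 1 to compound 2 (0.22 log units; within the scatter), a small move downward. Exchanging the amine head while shortening the chain gave a 2.7-fold lower number from compound 1 to compound 3 (0.44 log units; beyond the scatter). Among the measured compounds shown here, compound 4 lengthens the chain again and swaps the ring amine for one without the hydroxyl; no measured pair isolates the hydroxyl alone. Taken together these steps lead to an expected small downward move at most, estimated as a 1.6-fold lower number from compound 3 to compound 4 (0.21 log units; within the scatter), which would be within the scatter. In this assay compound 4 is therefore expected near 75 nM, with a range from 20 nM to 250 nM.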

Compound 4, half-maximal inhibitory concentration: 54 nM
Compound 4: the middle estimate sits 1.4-fold (0.14 log units) above what was measured, and the stated range covers the measured number.
By their numbers in this assay, from the lowest: compound 4; then compounds 3, 2 and 1 (each within the scatter of the next, the first and the last beyond it).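

In this assay, piperidin-1-yl in place of dimethylamino on a saturated chain carbon, six bonds along the chain from an oxygen on an aromatic ring, lowers the number beyond the scatter (a 6.2-fold lower number from compound 1 to compound 4 (0.79 log units; beyond the scatter)), and this is the first step shown in which the amine head changes while the chain stays the same. The two other new steps also lie beyond the scatter (a 3.7-fold lower number from compound 2 to compound 4 (0.57 log units; beyond the scatter); a 2.3-fold lower number from compound 3 to compound 4 (0.36 log units; beyond the scatter)), so compound 4 holds the lowest number of the four, whereas compound 3 could not be separated from compound 2.

Still open, on these data alone, is what 4-hydroxypiperidin-1-yl would give on the chain of compound 4, and whether a pyrrolidine or morpholine head, or a longer chain carrying piperidin-1-yl, would lower the number further. Nothing measured here accounts for any of these steps.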